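Bromine for chlorine on the ring bound to the chain

This account rests on a few compounds, and the source may have more. Where it says the series, first, only, none or still open, it means among the compounds named here.

Compound 1, `COc1cccc(/C=C2\NS(=O)(=O)c3ccccc3C2=O)c1`: in an assay for inhibition of alkaline phosphatase, tissue-nonspecific isozyme (Homo sapiens), read by spectrophotometry, with stated times of 10 min and 20 min (a higher number here means a weaker inhibitor, a lower number a stronger inhibitor), compound 1 gives > 200000 nM, which is a limit of the assay and not a number.
Compound 2, `O=C1/C(=C/c2ccc(Br)cc2)NS(=O)(=O)c2ccccc21`: in this assay compound 2 gives 1430 nM.

For the measured compounds named here, compound 2 holds the only real number here. The result for compound 1 is a limit. Going by the values given here, no two measured compounds differ in a single place, so no measured step exists to lean on. Compound 3, `O=C1/C(=C/c2cccc(Cl)c2)NS(=O)(=O)c2ccccc21`, differs from compound 2 by 3-chlorophenyl in place of 4-bromophenyl on a double-bonded chain carbon bound to a double-bonded ring carbon. The expected step of a 1.7-fold higher number from compound 2 to compound 3 (0.24 log units; within the scatter) is small, likely within the usual scatter, leaning if anything toward weaker inhibition. Compound 3 is therefore estimated at 2500 nM, with a range from 800 nM to 8000 nM.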

Compound 3, half-maximal inhibitory concentration: > 200000 nM
Compound 3 was reported as a limit (the forecaster's own chance of this, stated with the estimate: 5%); middle value at least 80-fold (1.90 log units) away from the limit.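

In this assay, the first readable step appears: an at least 130-fold higher number from compound 2 to compound 3 (2.14 log units; beyond the scatter). Both groups have the same heavy-atom count, yet this place on the chain responds sharply to the swap. The result for compound 3 is a limit of the assay and not a number, and the step between the two limits cannot be read: the limit of > 200000 nM in this assay, at which 2 of the 3 values shown sit.

The swap changes the halogen and its place on the ring together, and the compounds shown do not separate the two. As far as these compounds go, how an amine or a carboxylic acid on that ring would fare also remains open.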